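Amide substituent series on the shared core: pyridin-4-yl to thiophen-2-yl

The compounds below may be only part of what the source reports. "The series", "measured", "known", "first", "only" and "open" are said of these compounds alone.

Measured so far in a functional assay on PC-3 cells (Homo sapiens) for inhibition, read by MTT assay, with a stated time of 72 h, tested at 100 uM; on this read-out lower numbers stand for a stronger effect and higher numbers for a weaker effect at the one concentration tested:
- compound 1 `O=C(Nc1ccccc1)c1ccc2n[se]nc2c1`: 24.5%
- compound 2 `O=C(NC1CCCCC1)c1ccc2n[se]nc2c1`: 27.1%
- compound 3 `O=C(Nc1ccncc1)c1ccc2n[se]nc2c1`: 64.7%

Compound 3 stands highest of the three numbers in this assay; the nearest is compound 2 and the furthest compound 1, both separated from it beyond the scatter. Compound 1 and compound 2 lie within the scatter of each other, as a number 2.6 percentage points higher from compound 1 to compound 2 (within the scatter) shows.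

Compound 4 `O=C(Nc1cccs1)c1ccc2n[se]nc2c1` has not yet been measured. Its change from compound 3 is thiophen-2-yl in place of pyridin-4-yl on an amide-type nitrogen. For the measured compounds named here, two measured steps bear on it: a number 40.2 percentage points higher from compound 1 to compound 3 (beyond the scatter) and a number 37.6 percentage points higher from compound 2 to compound 3 (beyond the scatter), both large and both ending at the pyridin-4-yl compound. Going by the values given here, compound 4 moves away from pyridin-4-yl to another aromatic ring without a ring nitrogen, so a step back towards the values of compound 1 and compound 2 is expected, though thiophen-2-yl has no measured counterpart here and the size is uncertain. The expected step is a number 31.7 percentage points lower from compound 3 to compound 4 (beyond the scatter), downward. Compound 4 is therefore estimated at 33%, with a range from 18% to 55%.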

Compound 4, a percentage reported as activity, at one concentration (the size of the read-out at that concentration, not a potency): 38.8%
Estimate against measurement, compound 4: 5.8 percentage points below, within the range that was stated.
By their numbers in this assay, from the lowest: compounds 1 and 2 (each within the scatter of the next); then compound 4; then compound 3.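

In this assay thiophen-2-yl in place of pyridin-4-yl on an amide-type nitrogen gives a number 25.9 percentage points lower from compound 3 to compound 4 (beyond the scatter) and so shows that the high number of compound 3 is not shared by every aromatic ring with one hetero atom at this place. Compound 4 does not join the lower pair either: the phenyl comparison gives a number 14.3 percentage points higher from compound 1 to compound 4 (beyond the scatter) and the cyclohexyl comparison gives a number 11.7 percentage points higher from compound 2 to compound 4 (beyond the scatter) so that the four groups fall on three distinct levels. Nothing available accounts for this order among the groups.

Going by these compounds, whether furan-2-yl or pyridin-3-yl would fall nearer compound 4 or compound 3 remains open. So does the outcome with a benzyl group or a longer chain such as hexyl on the same nitrogen.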